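Silyl ether on the hydroxyl of a cyclopentenone series

The compounds below may be only part of what the source reports. "The series", "measured", "known", "first", "only" and "open" are said of these compounds alone.

Measured compounds in an ADME assay on MIA PaCa-2 cells (Homo sapiens) for cytotoxicity, read by MTT assay, with a stated time of 72 h; a lower number here means a stronger inhibitor, a higher number a weaker inhibitor:
compound 1 `COc1ccc(C2=C(c3cc(OC)c(OC)c(OC)c3)C(=O)CC2O[SiH2]C(C)(C)C)cc1`: > 100 ug/mL
compound 2 `COc1ccc(C2=C(c3cc(OC)c(OC)c(OC)c3)CC(O)C2=O)cc1[N+](=O)[O-]`: > 100 ug/mL
compound 3 `COc1ccc(C2=C(c3cc(OC)c(OC)c(OC)c3)C(=O)CC2O)cc1`: > 100 ug/mL

In this assay compound 3 gives a limit, > 100 ug/mL. Compound 1 likewise gives a limit, > 100 ug/mL. Compound 2 also gives only a limit, > 100 ug/mL. All three values therefore sit at the limit of > 100 ug/mL in this assay, at which 3 of the 3 values shown sit, and no number is available for any of them.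

The change from compound 3 to compound 1 is a group of 5 heavy atoms (4 carbon, 1 silicon; no ring) in place of a hydrogen atom, on an oxygen on a saturated carbon. Its size is a step that the two limits leave unreadable from compound 3 to compound 1; both values are limits, so no step can be read from it.

The cores of compound 2 and compound 3 differ, but the difference between the two cores is not broken down here.

Compound 4 `COc1ccc(C2=C(c3cc(OC)c(OC)c(OC)c3)CC(O[SiH2]C(C)(C)C)C2=O)cc1[N+](=O)[O-]` has not yet been measured in this assay. It differs from compound 2 by a group of 5 heavy atoms (4 carbon, 1 silicon; no ring) in place of a hydrogen atom, on an oxygen on a saturated carbon. This is the same change as that from compound 3 to compound 1, made on a second core.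

Because compound 3 and compound 1 both sit at the limit of > 100 ug/mL in this assay, at which 3 of the 3 values shown sit, the earlier instance of the change gives no readable step, and the step from compound 2 to compound 4 is expected to be a step that the limit leaves unreadable from compound 2 to compound 4, with a further limit rather than a number the most likely outcome. The value expected for compound 4 in this assay is 150 ug/mL, within a range from 60 ug/mL to 400 ug/mL.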

Compound 4, half-maximal inhibitory concentration: > 100 ug/mL
Compound 4 was reported as a limit; the forecaster's own chance of this, stated with the estimate: 85%; the middle value is on the limit's open side.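

In this assay compound 4 gives > 100 ug/mL, which is a limit and not a number. With limits on both sides, no new step can be read from compound 2 to compound 4. All four compounds stand at the same value: the limit of > 100 ug/mL in this assay, at which 4 of the 4 values shown sit.

The compounds shown leave open how large the change on the oxygen is on either core in this assay.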